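This account rests on a few compounds, and the source may have more. Where it says the series, first, only, none or still open, it means among the compounds named here.

Compound 3 `c1ccc(CNCC2CCN(CCCc3c[nH]c4ccc(-n5cnnc5)cc34)CC2)cc1` stands second highest of the three numbers recorded so far. In an assay on CHO cells for displacement of a labelled ligand from 5-hydroxytryptamine receptor 1D (Homo sapiens) (on this read-out lower numbers stand for stronger inhibition and higher numbers for weaker inhibition), compound 3 gives 1.6 nM, a result that sits alongside that of compound 1 `C[C@@H](NCC1CCN(CCCc2c[nH]c3ccc(-n4cnnc4)cc23)CC1)c1ccccc1`, which in this assay gives 1.4 nM, while compound 2 `O[C@H]1Cc2ccccc2C1NC1CCN(CCCc2c[nH]c3ccc(-n4cnnc4)cc23)CC1` in this assay gives 37 nM. Two measured steps reach compound 3: a 1.1-fold higher number from compound 1 to compound 3 (0.06 log units; within the scatter), which shows that trimming the group on the saturated ring carbon barely moves the number, and a 23-fold lower number from compound 2 to compound 3 (1.36 log units; beyond the scatter), which shows that exchanging the whole group on that carbon can shift it a great deal. Compound 4 `CC(C)=CCCN(C)C1CCN(CCCc2c[nH]c3ccc(-n4cnnc4)cc23)CC1` carries a new change there: methyl(4-methylpent-3-en-1-yl)amino in place of (benzylamino)methyl on a saturated ring carbon. Within the data shown here, no measured pair isolates this exact exchange, but the large swing seen in a 23-fold lower number from compound 2 to compound 3 (1.36 log units; beyond the scatter) indicates that the identity of the group on this ring carbon is decisive, and the aromatic ring and hydrogen-bond donor that leave are shared by the two strongest compounds. Compound 4 is therefore expected to weaken, with a step of a 9.4-fold higher number from compound 3 to compound 4 (0.97 log units; beyond the scatter). The estimate for compound 4 in this assay is 15 nM, within a range from 3 nM to 80 nM.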

Compound 4, half-maximal inhibitory concentration: 2.6 nM
Compound 4: the middle estimate sits 5.8-fold (0.76 log units) above what was measured, and the stated range ends above it.
By their numbers in this assay, from the lowest: compounds 1, 3 and 4 (each within the scatter of the next); then compound 2.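

In this assay, the step of a 1.6-fold higher number from compound 3 to compound 4 (0.21 log units; within the scatter) shows that the aromatic ring and the hydrogen-bond donor of (benzylamino)methyl can both leave this saturated ring carbon with the result staying within the scatter, and a 1.9-fold higher number from compound 1 to compound 4 (0.27 log units; within the scatter) reads the same way against ((1-phenylethyl)amino)methyl. Among these compounds, the ringless methyl(4-methylpent-3-en-1-yl)amino therefore matches both of those groups, while the large step of a 14-fold lower number from compound 2 to compound 4 (1.15 log units; beyond the scatter) leaves (2-hydroxy-2,3-dihydro-1H-inden-1-yl)amino as the one group of the four that stands apart. Nothing available explains this result.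

The compounds shown leave open whether the double bond of the entering chain matters, since no saturated 4-methylpentyl chain appears among them. They also leave open how a carboxylic acid or a morpholine on this ring carbon would read.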